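The source may report more compounds than this note shows. Statements on the series, on what has been measured and on what is new or still open speak of the compounds shown alone.

Working notes on the series. Among the compounds with values here, in a functional assay on the whole organism with Mus musculus as the target, read by paw edema, with a stated time of 360 min, at a dose of 50 mg/kg by the oral route (on this read-out higher numbers stand for a weaker effect at the one dose given and lower numbers for a stronger effect), compound 3 `CCCNC(=S)NNC(=O)Cn1c(=O)oc2ccc(C)cc21` gives 177%, the highest of the three numbers measured so far. Compound 1 `CCn1c(Cn2c(=O)oc3ccc(C)cc32)n[nH]c1=S` gives 147% and compound 2 `Cc1ccc2oc(=O)n(CC(=O)NN)c2c1` gives 101%; the distance from compound 3 to each of them lies beyond the scatter, so compound 3 stands as the weakest of the three on this read-out at the dose given. Within the data shown here, the single measured step is a number 76 percentage points higher from compound 2 to compound 3 (beyond the scatter), a group of 6 heavy atoms in place of a hydrogen atom on an amine nitrogen, which is a large move. Compound 4 `CCNC(=S)NNC(=O)Cn1c(=O)oc2ccc(C)cc21` differs from compound 3 by hydrogen in place of methyl on a saturated chain carbon, two bonds along the chain from an amide-type nitrogen — propyl to ethyl, cut one bond further out. Among the measured compounds shown here, no measured step shortens a chain at this place; the recorded step a number 76 percentage points higher from compound 2 to compound 3 (beyond the scatter) concerns attachment of the whole group, not the length of its chain, so it gives no direction for a change of one carbon. Compound 4 is expected to land near compound 3, at 170%, within 140% to 200%. The expected step of a number 7 percentage points lower from compound 3 to compound 4 (within the scatter) is estimated not to reach beyond the scatter.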

Compound 4, a percentage reported as activity, at one dose (the size of the read-out at that dose, not a potency): 128%
For compound 4 the middle estimate is 42 percentage points above the measured one; measured number outside the range, below it.
By their numbers in this assay, from the lowest: compound 2; then compound 4; then compound 1; then compound 3.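

In this assay, the cut from propyl to ethyl alone gives a number 49 percentage points lower from compound 3 to compound 4 (beyond the scatter), so at this place the read-out depends on the length of the chain and not only on attachment of the whole group. Attachment still raises the number with the ethyl chain, at a number 27 percentage points higher from compound 2 to compound 4 (beyond the scatter), but this modest step is smaller than the large a number 76 percentage points higher from compound 2 to compound 3 (beyond the scatter), so part of the weakening seen with propyl falls away with one carbon fewer. Nothing available accounts for why one carbon matters this much.

As far as these compounds go, two chain lengths fix no trend, so it stays open whether a methyl group would lower the number further or whether a butyl chain would raise it. Also open, from the compounds shown here alone, is whether any group at this place could bring the number under that of compound 2.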